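A fluoro added to compound 2: what to expect

A few compounds are considered here, and "the series" means these few. Any claim that something is new, unique, unknown or untested is made for them only; others in the source may bear on it.

In an ADME assay for permeability, using PAMPA, at pH 6.5 (a higher number here means that the compound crosses the layer faster, a lower number that the compound crosses the layer more slowly), compound 1 (`CNS(=O)(=O)Nc1cccc(Cc2c(C)c3ccc(Oc4ncccn4)cc3oc2=O)c1`) gives 6 10^-6 cm/s and compound 2 (`CNS(=O)(=O)Nc1cccc(Cc2c(C)c3ccc(Oc4nccs4)cc3oc2=O)c1`) gives 2 10^-6 cm/s as the lower of the two numbers. Compound 3 (`CNS(=O)(=O)Nc1cccc(Cc2c(C)c3ccc(Oc4nccs4)cc3oc2=O)c1F`) differs from compound 2 in one place (fluoro in place of hydrogen on an aromatic carbon) with fluoro in place of hydrogen on an aromatic carbon. Going by the values given here, the only measured step is a 3.0-fold lower number from compound 1 to compound 2 (0.48 log units; beyond the scatter) and it concerns a different group, so it gives no direct guide to this change. Among the compounds with values here, with no measured fluoro step to go on, the expected change is a 1.5-fold higher number from compound 2 to compound 3 (0.18 log units; within the scatter) and nothing beyond the scatter is expected. Compound 3 is estimated at 3 10^-6 cm/s with an expected range of 1.2 10^-6 cm/s to 8 10^-6 cm/s in this measurement.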

Compound 3, apparent permeability: 3 10^-6 cm/s
The estimate for compound 3 equals the measured number at the digits printed, and the stated range covers the measured number.
By their numbers in this assay, from the lowest: compounds 2, 3 and 1 (each within the scatter of the next, the first and the last beyond it).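

Fluoro in place of hydrogen on this aromatic carbon, ortho to a (methylsulfamoyl)amino group, gives a 1.5-fold higher number from compound 2 to compound 3 (0.18 log units; within the scatter) in this assay. Going by these compounds alone, this position therefore tolerates this small change without a shift beyond the scatter, which is the first reading on this ring of the molecule. Nothing measured here gives a reason for this result. Going by these compounds, whether a larger group at the same position, such as an amine, a methoxy or a trifluoromethyl, would also stay within the scatter remains open. So does whether fluoro would behave the same way in compound 1.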